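A few compounds are considered here, and "the series" means these few. Any claim that something is new, unique, unknown or untested is made for them only; others in the source may bear on it.

Measured compounds:
Compound 1 `NC1=C(Cl)C(=O)c2ncccc2C1=O` gives > 200000 nM in a functional assay on cells (Neutrophil, Homo sapiens) for inhibition, read by WST assay, with a stated time of 20 min (a higher number here means a weaker inhibitor, a lower number a stronger inhibitor), a limit of the assay.
Compound 2 `CS(=O)(=O)C1=C(N)C(=O)c2cccnc2C1=O` gives > 200000 nM in this assay, also a limit.
Compound 3 `CNC1=C([S+](C)[O-])C(=O)c2ncccc2C1=O` gives > 200000 nM in this assay, again a limit.

None of the three measured compounds shows inhibition within the reach of this assay; all three values sit at the limit of > 200000 nM in this assay, at which 3 of the 3 values shown sit. Compound 3 therefore stands at the limit, with no number of its own to place it. Going by the values given here, the one step between measured compounds that differ in a single place, a step that the two limits leave unreadable from compound 1 to compound 2, cannot be read, since both of its ends are limits.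

Compound 4 `C[S+]([O-])C1=C(N)C(=O)c2cccnc2C1=O` differs from compound 3 by hydrogen in place of methyl on an amine nitrogen. Among the compounds with values here, no measured step touches this amine nitrogen, so no step bears directly on the change. Within the data shown here, the only guidance is that every compound of this shared core measured so far sits at the limit, and the small change of a methyl for a hydrogen gives no reason to expect a different outcome. The expected step from compound 3 is a step that the limit leaves unreadable from compound 3 to compound 4, that is, none that the assay could show. Compound 4 is therefore expected to remain at the limit, with an estimate of 300000 nM and a range from 100000 nM to 1000000 nM.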

Compound 4, half-maximal inhibitory concentration: > 200000 nM
Compound 4: only a limit was reported; the forecaster's own chance of this, stated with the estimate: 90%; the middle value does not contradict the limit.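

In this assay compound 4 gives > 200000 nM and this is a limit, not a number. Going by these compounds alone, no step from compound 1, compound 2 or compound 3 to compound 4 can be read, as each has a limit at both ends: the limit of > 200000 nM in this assay, at which 4 of the 4 values shown sit. The compounds shown leave open whether any change to the shared core can give a readable value in this assay at all.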